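A single stereocentre inverted at the limit

The source may hold more compounds than are shown below. What is called first, only, known or untested is meant among the compounds shown, and "the series" means these compounds.

compound 1 `CN1C(=S)[C@@H](NC(=O)c2n[nH]c(Cc3ccccc3)n2)COc2ncccc21` gives > 50000 nM (a limit)
compound 2 `CN1C(=S)[C@H](NC(=O)c2n[nH]c(Cc3ccccc3)n2)COc2ncccc21` gives > 50000 nM (a limit)
compound 3 `Cc1cnc2c(c1)N(C)C(=S)[C@@H](NC(=O)c1n[nH]c(Cc3ccccc3)n1)CO2` gives > 50000 nM (a limit)

In an ADME assay on HT-29 cells (Homo sapiens) for cytotoxicity, read by luminescence and CellTiter-Glo, with a stated time of 10 h (on this read-out higher numbers stand for lower toxicity in this test and lower numbers for higher toxicity in this test), compound 3 gives > 50000 nM as a limit and not as a number. Going by the values given here, no measured compound has a number to rank it against, and the only fixed point is the limit of > 50000 nM in this assay, at which 3 of the 3 values shown sit, for the whole set.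

In the change to compound 4 `Cc1cnc2c(c1)N(C)C(=S)[C@H](NC(=O)c1n[nH]c(Cc3ccccc3)n1)CO2` nothing leaves and nothing enters, and in words the two compounds have the same atoms and bonds and differ only in configuration as drawn: 1 of 1 stereo elements differ; a stereocentre at a saturated ring carbon is drawn S in compound 3 and R in compound 4 is the whole of it.

Among the compounds with values here, the nearest precedent is the same kind of inversion, a step that the two limits leave unreadable from compound 1 to compound 2 without any readable size or direction. The other measured step is a step that the two limits leave unreadable from compound 1 to compound 3 for methyl in place of hydrogen on an aromatic carbon, and it is equally unreadable. Compound 2, the partner drawn R, gives > 50000 nM as a limit too.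

On that precedent no change beyond the usual scatter is expected in this assay and no direction can be given, so the expected size is a number no higher from compound 3 to compound 4 (the limit leaves the size open) for this inversion. Compound 4 is therefore estimated at 50000 nM with an expected range from 25000 nM to 100000 nM and will most likely be reported only as a limit again.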

Compound 4, half-maximal cytotoxic concentration: > 50000 nM
Compound 4: only a limit was reported (the forecaster's own chance of this, stated with the estimate: 90%); the middle value sits exactly at the limit.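

In this assay, compound 2, compound 3 and compound 4 are all reported only as limits, so neither the inversion linking compound 3 to compound 4 nor the methyl in place of hydrogen on an aromatic carbon linking compound 2 to compound 4 can be read. The compounds shown leave open whether either change alters cytotoxicity beyond that limit.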